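A few compounds are considered here, and "the series" means these few. Any claim that something is new, unique, unknown or untested is made for them only; others in the source may bear on it.

Measured so far in an assay on CHO cells for displacement of a labelled ligand from 5-hydroxytryptamine receptor 1D (Homo sapiens); on this read-out higher numbers stand for weaker inhibition and lower numbers for stronger inhibition:
compound 1, `c1ccc(C2CCCCN2C2CCN(CCCc3c[nH]c4ccc(-n5cnnc5)cc34)CC2)cc1`: 1.9 nM
compound 2, `CN(Cc1ccc(S(C)(=O)=O)cc1)C1CCN(CCCc2c[nH]c3ccc(-n4cnnc4)cc23)CC1`: 18 nM
compound 3, `CN(Cc1ccco1)C1CCN(CCCc2c[nH]c3ccc(-n4cnnc4)cc23)CC1`: 9.3 nM

Compound 3 gives 9.3 nM in this assay, the second highest of the three numbers. Its nearest neighbour is compound 2 at 18 nM; the step of a 1.9-fold lower number from compound 2 to compound 3 (0.29 log units; within the scatter) lies within the scatter. Furthest away is compound 1 at 1.9 nM, whose gap to compound 3 goes beyond the scatter.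

Compound 4, `O[C@@H]1Cc2ccccc2[C@H]1NC1CCN(CCCc2c[nH]c3ccc(-n4cnnc4)cc23)CC1`, awaits measurement. Against compound 3 the change is (2-hydroxy-2,3-dihydro-1H-inden-1-yl)amino in place of ((furan-2-yl)methyl)(methyl)amino on a saturated ring carbon.

Among the measured compounds shown here, the only measured step at a related place is a 1.9-fold lower number from compound 2 to compound 3 (0.29 log units; within the scatter), and it stayed within the scatter, so exchanging one ring on the saturated chain carbon for another left the number essentially unchanged. The present change is larger: a secondary amine with two defined stereocentres and a fused ring system enters where a methylated amine with a furan-2-yl arm stood. For the measured compounds named here, compound 1, which also carries a ring-rich substituent on the same saturated ring carbon, gives the lowest number of the three, which suggests the direction, though no single step supports it directly. A modest move toward lower numbers is therefore expected for compound 4, about a 1.9-fold lower number from compound 3 to compound 4 (0.27 log units; within the scatter).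

Compound 4 is estimated at 5 nM, with a range of 1.5 nM to 16 nM.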

Compound 4, half-maximal inhibitory concentration: 6.6 nM
Estimate against measurement, compound 4: 1.3-fold (0.12 log units) below; low and high end bracket the measured number.
By their numbers in this assay, from the lowest: compound 1; then compounds 4, 3 and 2 (each within the scatter of the next, the first and the last beyond it).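

On the saturated ring carbon, (2-hydroxy-2,3-dihydro-1H-inden-1-yl)amino in place of ((furan-2-yl)methyl)(methyl)amino gives a 1.4-fold lower number from compound 3 to compound 4 (0.15 log units; within the scatter) in this assay. Among the compounds shown here, the one earlier step changed only the ring on the saturated chain carbon of the amine arm, whereas this step replaces the whole amino substituent on the ring carbon, and the entering group brings a fused ring system, hydrogen-bond donors and 2 defined stereocentres, yet the number still stays within the scatter, so in this pair this assay does not register the exchange as a real change. No measurement available here connects this outcome to any property of either group.

From the compounds shown here alone, the hydroxyl, the fused ring system and the defined stereocentres all enter together, so their separate contributions remain open, and the plain (2,3-dihydro-1H-inden-1-yl)amino group or the opposite stereoisomers of the entering group would be needed to tell them apart. Also open, going by these compounds, is whether a simple benzylamino group or a carboxylic acid on the same saturated ring carbon would leave the number in this assay equally unchanged.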